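The compounds below may be only part of what the source reports. "The series", "measured", "known", "first", "only" and "open" are said of these compounds alone.

Measured so far in an ADME assay on the whole organism with Oryza sativa as the target, tested at 10 uM; on this read-out lower numbers stand for a stronger effect and higher numbers for a weaker effect at the one concentration tested:
- compound 1 `Cc1ccc(NC(=O)N[C@H](C)c2ccccc2)cc1` gives 64%
- compound 2 `Cc1ccc(NC(=O)N[C@@H](C)c2ccccc2)cc1` gives 100%
- compound 3 `CCOC(=O)c1cccc(NC(=O)N[C@H](C)c2ccccc2)c1` gives 88%

Compound 2 has the highest number of the three, so the weakest effect; compound 3 sits lower and compound 1 lowest, both gaps beyond the scatter. Among the compounds with values here, the only clean step among the measured compounds is a number 36 percentage points higher from compound 1 to compound 2 (beyond the scatter), and it rests on the fact that compounds 1 and 2 differ only in the configuration as drawn alone. Within the data shown here, compound 3 differs from compound 2 in more than one place, so no single step can be drawn from it.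

Compound 4 `CC(=O)c1ccc(NC(=O)N[C@@H](C)c2ccccc2)cc1` is not yet measured. The change from compound 2 is acetyl in place of methyl on an aromatic carbon. Among the measured compounds shown here, no measured step involves a change of this kind, so there is no direct guide to its size or direction. With compound 2 already at the weak end of the scale, the step is expected to be a number 10 percentage points lower from compound 2 to compound 4 (within the scatter), which is within the scatter. Compound 4 is therefore estimated to give 90%, in a range from 68% to 100%.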

Compound 4, a percentage reported as activity, at one concentration (the size of the read-out at that concentration, not a potency): 96%
The estimate for compound 4 lay 6 percentage points below the measured number, within the range that was stated.
By their numbers in this assay, from the lowest: compound 1; then compounds 3, 4 and 2 (each within the scatter of the next, the first and the last beyond it).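

In this assay, acetyl in place of methyl on an aromatic carbon, para to a large group, gives a number 4 percentage points lower from compound 2 to compound 4 (within the scatter). This swap brings in a larger group with a hydrogen-bond acceptor, yet the two compounds cannot be told apart here, so this change at this position shows no effect that can be claimed. Within the data shown here, the only other single step, a number 36 percentage points higher from compound 1 to compound 2 (beyond the scatter), does lie beyond the scatter, and what sets that pair apart is this: the fact that compounds 1 and 2 differ only in the configuration as drawn.

From the compounds shown here alone, it remains open whether acetyl would behave the same way with the configuration drawn in compound 1, which gives a lower number in this assay. Going by these compounds, it is also open whether another group at this place, such as an amine, a carboxylic acid or a longer chain, would move the number beyond the scatter.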